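The source may report more compounds than this note shows. Statements on the series, on what has been measured and on what is new or still open speak of the compounds shown alone.

Three compounds with a shared core are in hand. Compound 1, `Cc1c(OCCCCOc2ccc(C(=O)CC(C)(C)C)c(O)c2C)cccc1C(=O)O`, gives 136 nM in an assay on HEK293 cells for positive allosteric modulation of metabotropic glutamate receptor 2 (Rattus norvegicus), read by thallium flux, with a stated time of 2.5 min; a higher number here means that more compound is needed for the effect, a lower number that less compound is needed. Compound 2, `CCC(=O)c1ccc(OCCCCOc2ccc(F)c(C(=O)O)c2)c(C)c1O`, gives 124 nM in this assay, and compound 3, `Cc1c(OCCCCOc2ccc(F)c(C(=O)O)c2)ccc(C(=O)CC2CCCC2)c1O`, gives 699 nM. Compound 3 thus stands highest of the three numbers; compound 1 is nearest to it and compound 2 furthest, both below it by more than the scatter. Among the measured compounds shown here, the one single-point step known is a 5.6-fold higher number from compound 2 to compound 3 (0.75 log units; beyond the scatter).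

Compound 4, `Cc1c(OCCCCOCOc2ccc(C(=O)O)cc2)ccc(C(=O)CC2CCCC2)c1O`, is the next one to be measured. Relative to compound 3 the change is (4-carboxyphenoxy)methyl in place of 3-carboxy-4-fluorophenyl on an oxygen on a saturated carbon. For the measured compounds named here, the only measured step concerns the group on the saturated chain carbon bound to the carbonyl carbon, not the oxygen on the saturated carbon where this change sits, so no measured step bears directly on it. Compounds 1 and 2 differ from each other in more than one place, so their two values show only that two different carboxy-bearing aryl groups can sit there with numbers close to one another. With no direct guide, the step from compound 3 to compound 4 is expected to be a 1.3-fold higher number from compound 3 to compound 4 (0.11 log units; within the scatter), with wide uncertainty. Compound 4 is therefore estimated at 900 nM in this assay, within 250 nM to 3500 nM.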

Compound 4, half-maximal effective concentration: 228 nM
Compound 4: middle estimate off by 3.9-fold (0.60 log units), on the high side, outside the stated range (below it).
By their numbers in this assay, from the lowest: compounds 2, 1 and 4 (each within the scatter of the next); then compound 3.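

At the oxygen on a saturated carbon, putting (4-carboxyphenoxy)methyl in place of 3-carboxy-4-fluorophenyl gives a 3.1-fold lower number from compound 3 to compound 4 (0.49 log units; beyond the scatter) in this assay, the first single-place step measured at this position, since compounds 1 and 2 differ from each other in more than one place and could not isolate it. The step shows that the number responds to the group at this oxygen and that the fluorine-bearing group is not needed for the lower number of compound 4, although the entering group differs in several ways at once: it has no fluorine, it gains a further oxygen and a methyl link, and its carboxy group stands at a different numbered place on the ring. No measurement is available that explains this step.

The compounds shown leave open which of these differences accounts for the step, a question that 3-carboxyphenyl without the fluorine, or (3-carboxyphenoxy)methyl, would address directly. They also leave open whether the same change holds with the shorter propanoyl group of compound 2, and whether an amide or a tetrazole could stand in for the carboxylic acid.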